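Trifluoromethyl to Fluoro at a Near-Zero Read-Out

The source may hold more compounds than are shown below. What is called first, only, known or untested is meant among the compounds shown, and "the series" means these compounds.

Three compounds have been measured in a functional assay on CHO cells with adenosine receptor A1 (Homo sapiens) as the target, read by cAMP accumulation and immunoassay, with a stated time of 6 min, tested at 0.1 uM; a lower number here means a stronger effect, a higher number a weaker effect of the compound at the concentration tested:
compound 1, `Nc1scc(CN2CCN(c3ccccc3C(F)(F)F)CC2)c1C(=O)c1ccc(Cl)cc1`, gives -7.5%;
compound 2, `Nc1scc(CN2CCC(c3ccc(Cl)cc3)CC2)c1C(=O)c1ccc(Cl)cc1`, gives -2.3%;
compound 3, `Nc1scc(CN2CCN(c3c(F)cccc3F)CC2)c1C(=O)c1cccc(C(F)(F)F)c1`, gives 1.3%.

Compound 1 has the lowest of the three numbers, but compound 2, the nearest to it, lies within the scatter of repeated measurements, and so does compound 3, the furthest. All three read out as essentially no effect at the tested concentration, and no order among them can be claimed.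

Compound 4, `Nc1scc(CN2CCN(c3ccccc3F)CC2)c1C(=O)c1ccc(Cl)cc1`, has not yet been measured. It differs from compound 1 in one place: fluoro in place of trifluoromethyl on an aromatic carbon. The rest of the molecule is unchanged.

Going by the values given here, no two measured compounds differ in only one place, so no measured step shows how large such a change tends to be here. For compound 4 the expected step of a number 4.5 percentage points higher from compound 1 to compound 4 (within the scatter) is none beyond the scatter. Compound 1 gives -7.5%, a number that already shows no effect. Both other measured compounds sit within the scatter of it. Compound 4 is therefore estimated to give -3%, with an expected range from -15% to 10%.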

Compound 4, a percentage reported as activity, at one concentration (the size of the read-out at that concentration, not a potency): -1%
Estimate against measurement, compound 4: 2 percentage points below; the measured number falls inside the stated range.
By their numbers in this assay, from the lowest: compounds 1, 2, 4 and 3 (each within the scatter of the next).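

In this assay, going by these compounds alone, the change from 2-(trifluoromethyl)phenyl to 2-fluorophenyl gives a number 6.5 percentage points higher from compound 1 to compound 4 (within the scatter), and this is the first step in the set that alters one place only. It shows that at this position, on an aromatic carbon ortho to a large group, a group of 4 heavy atoms can give way to a single fluorine without moving the read-out beyond the usual scatter, so both compounds still read as essentially no effect at the tested concentration. Nothing available explains why the read-out stays where it does, and no measured property of either group bears on this result.

With both numbers near zero at a single concentration, this step cannot show whether the change would matter at a concentration where an effect appears. It also leaves open whether a different group at this position, such as an amine, a carboxylic acid or a longer chain, would move the read-out clearly away from zero.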